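Swapping the butenyl arm for a cyclohexyl ring

The source may report more compounds than this note shows. Statements on the series, on what has been measured and on what is new or still open speak of the compounds shown alone.

Compound 2 `C=CCC/C(C)=N\Nc1nc(-c2cccc([N+](=O)[O-])c2)cs1` gives the lowest number of the three measured compounds in an assay on isolated protein for inhibition of Amine oxidase [flavin-containing] A (Homo sapiens), read by fluorescence, with a stated time of 20 min (on this read-out higher numbers stand for weaker inhibition and lower numbers for stronger inhibition), at 3990 nM, although compound 3 stands within the scatter of it. Compound 1 `CCC/C(C)=N\Nc1nc(-c2cccc([N+](=O)[O-])c2)cs1` gives 38000 nM, and compound 3 `CCC/C(CC)=N\Nc1nc(-c2cccc([N+](=O)[O-])c2)cs1` gives 4860 nM. The step from compound 2 to compound 3 is a 1.2-fold higher number from compound 2 to compound 3 (0.09 log units; within the scatter), so these two cannot be set in order. Compound 4 `C/C(=N/Nc1nc(-c2cccc([N+](=O)[O-])c2)cs1)C1CCCCC1` is not yet measured; it differs from compound 2 by cyclohexyl in place of but-3-en-1-yl on a carbon with a double bond to nitrogen. Two measured steps enlarge the same side of the shared core: a 9.5-fold lower number from compound 1 to compound 2 (0.98 log units; beyond the scatter) and a 7.8-fold lower number from compound 1 to compound 3 (0.89 log units; beyond the scatter), both lowering the number. Neither puts a ring in this place, so they bear on the change only loosely. Because both a 9.5-fold lower number from compound 1 to compound 2 (0.98 log units; beyond the scatter) and a 7.8-fold lower number from compound 1 to compound 3 (0.89 log units; beyond the scatter) point downward, a further small drop or no step beyond the scatter is expected, the estimated step being a 1.3-fold lower number from compound 2 to compound 4 (0.12 log units; within the scatter). Compound 4 is expected to give 3000 nM, within a range from 600 nM to 15000 nM.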

Compound 4, half-maximal inhibitory concentration: 29100 nM
Estimate against measurement, compound 4: 9.7-fold (0.99 log units) below, and the stated range ends below it.
By their numbers in this assay, from the lowest: compounds 2 and 3 (each within the scatter of the next); then compounds 4 and 1 (each within the scatter of the next).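

At this carbon with a double bond to nitrogen, adding heavy atoms does not by itself go with a lower number in this assay: compound 4 goes against the trend set by compound 2 and compound 3 (a 7.3-fold higher number from compound 2 to compound 4 (0.86 log units; beyond the scatter)). Against the shorter propyl chain of compound 1, the cyclohexyl ring brings no step that can be told from scatter (a 1.3-fold lower number from compound 1 to compound 4 (0.12 log units; within the scatter)), so this ring keeps none of the gain seen with the two longer or larger open-chain compounds. Nothing measured here explains why the ring and the open chains part ways.

The compounds shown leave open whether a smaller ring, such as cyclopropyl, would group with compound 4 or with compound 2. They also leave open how a phenyl ring or a longer chain, such as hexyl, would read at this carbon.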